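Bulkier Group on the Core, Beyond the Upper Limit

The compounds below may be only part of what the source reports. "The series", "measured", "known", "first", "only" and "open" are said of these compounds alone.

Compound 1 `Cc1cc(C(N)=O)nn1Cc1cc(Cl)ccc1OCc1ccccc1` carries a carbamoyl group on its five-membered core. Among the compounds with values here, in a physicochemical assay for lipophilicity, at pH 7.4 (on this read-out higher numbers stand for higher lipophilicity and lower numbers for lower lipophilicity), compound 1 gives 3.7, the only plain number among the values shown. Compound 2 `Cc1cc(C(=O)NCc2ccccn2)nn1Cc1cc(Cl)ccc1OCc1ccccc1` carries a (pyridin-2-yl)methyl group on the amide-type nitrogen. In this assay compound 2 gives > 3.7, which is a limit of the assay and not a number. The step of a number no lower from compound 1 to compound 2 (the limit leaves the size open) therefore has a direction but no readable size, and it marks where the ceiling of this assay sits, namely (the limit of > 3.7 in this assay, at which 1 of the 2 values shown sits).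

Compound 3 `Cc1cc(NC(=O)OC(C)(C)C)nn1Cc1cc(Cl)ccc1OCc1ccccc1` has not yet been measured. It differs from compound 1 by (tert-butoxycarbonyl)amino in place of carbamoyl on an aromatic carbon. Within the data shown here, no measured step changes this group, so the step from compound 1 to compound 2 bears only loosely on it, as the one example of a larger group entering the same core and carrying the value past the ceiling. With a larger group entering again, the step from compound 1 to compound 3 is expected to be a number 1.10 log units higher from compound 1 to compound 3 (beyond the scatter). Compound 3 is estimated at 4.8, with a range from 4.2 to 5.4, and the assay is expected most likely to report only its limit.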

Compound 3, distribution coefficient: > 3.7
Compound 3: no number, only a limit; the forecaster's own chance of this, stated with the estimate: 70%; the middle value is on the limit's open side.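

Swapping the whole carbamoyl group, and not only adding to its nitrogen, still gives a number no lower from compound 1 to compound 3 (the limit leaves the size open), so at this aromatic carbon two different replacements have now moved the read-out in this assay in the same direction. The (tert-butoxycarbonyl)amino group that enters has 8 heavy atoms against 3 for the carbamoyl it replaces, while its count of hydrogen-bond donors stays the same, and the result is again a limit and not a number. With this result, the ceiling of the assay now holds most of the series: the limit of > 3.7 in this assay, at which 2 of the 3 values shown sit.

The step between compound 2 and compound 3 cannot be read, and neither limit tells how far past the ceiling that compound lies, so the two cannot be ranked against each other or against the size of any change. From the compounds shown here alone, whether a small group on the same carbon, such as a free amine or a carboxylic acid, would bring the value back to a plain number remains open.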